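The compounds below may be only part of what the source reports. "The series", "measured", "known", "first", "only" and "open" are said of these compounds alone.

Compound 1, `O=S(=O)(Nc1ccc2oc(-c3ccccc3)nc2c1)c1ccccc1O`, in an assay on cells for inhibition of HSP60/HSP10 (Homo sapiens), with a stated time of 60 min; a lower number here means a stronger inhibitor, a higher number a weaker inhibitor: 85000 nM.
Compound 2, `O=S(=O)(Nc1ccc2oc(-c3ccccc3)nc2c1)c1ccccc1Cl`, in this assay: > 100000 nM, a limit of the assay rather than a number.
Compound 3, `COc1cccc(S(=O)(=O)Nc2ccc3oc(-c4ccccc4)nc3c2)c1`, in this assay: > 100000 nM, again a limit of the assay and not a number.

Compound 3 therefore stands only at the ceiling of this assay; of the three values in hand, two sit there, as the limit of > 100000 nM in this assay, at which 2 of the 3 values shown sit, records. Compound 4 is `O=S(=O)(Nc1ccc2oc(-c3ccccc3)nc2c1)c1cccc(F)c1`, and the change from compound 3 is fluoro in place of methoxy on an aromatic carbon.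

Among the measured compounds shown here, two measured steps touch compound 3. One is an at least 1.1-fold higher number from compound 1 to compound 3 (0.07 log units; that floor lies within the scatter). The other is a step that the two limits leave unreadable from compound 2 to compound 3. For the measured compounds named here, neither gives a readable size, and no step in the set moves beyond the scatter. The whole series, including compound 1 with its number, lies at or near the ceiling, so there is no measured substituent effect from which a direction for fluoro in place of methoxy could be taken.

The expectation for compound 4 in this assay is accordingly a step of about a number no higher from compound 3 to compound 4 (the limit leaves the size open), that is, no movement beyond the scatter from the limit. Compound 4 is estimated at 100000 nM, with a range from 40000 nM to 300000 nM, and most likely the assay will again report only a limit.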

Compound 4, half-maximal inhibitory concentration: > 100000 nM
Compound 4 was reported as a limit (the forecaster's own chance of this, stated with the estimate: 65%); the middle value lies on the limit itself.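

Fluoro in place of methoxy shows that a second group on this aromatic carbon, meta to a large group, also leaves the compound at the ceiling of this assay, with 3-fluorophenyl now reading no differently from 3-methoxyphenyl; the steps to compound 4 from compound 3 and from compound 2 cannot be read, as both ends of each are limits. Among the compounds shown here, the one readable step is an at least 1.1-fold higher number from compound 1 to compound 4 (0.07 log units; that floor lies within the scatter), so even the comparison with the only compound that has a number shows no movement beyond the scatter. Losing the methoxy oxygen and carbon for a single fluorine therefore produces no measurable response at this position, and the ceiling now covers most of the set, compound 1 being the single exception: the limit of > 100000 nM in this assay, at which 3 of the 4 values shown sit.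

Still open, going by these compounds, is whether any group on this ring can bring a value clearly below the ceiling, as no ranking of substituents can be drawn from these compounds. An amine or a carboxylic acid at this position, or 3-hydroxyphenyl on the sulfonyl sulfur, would test this, the last also showing whether the hydroxy of compound 1 gives a number at this other place.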